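Fluoro for formyl on a shared core: an inactive pair

This account rests on a few compounds, and the source may have more. Where it says the series, first, only, none or still open, it means among the compounds named here.

Measured so far:
- compound 1, `COc1cc2c(cc1OC)CN(c1ccc(C=O)cc1)CC2`: > 100000 nM
- compound 2, `COc1cc2c(cc1OC)CN(c1cc(F)cc(F)c1)CC2`: > 100000 nM

Both compounds share one core and differ only in the aromatic ring carried on the nitrogen. They were tested in an assay on isolated protein for inhibition of Amine oxidase [flavin-containing] A (Homo sapiens), with a stated time of 1 h; on this read-out lower numbers stand for stronger inhibition and higher numbers for weaker inhibition. Compound 1 gives > 100000 nM, which is a limit of the assay and not a number. Compound 2 gives > 100000 nM, also a limit. Within the data shown here, compound 1 therefore stands at the edge of what this assay can report, and so does the one other value shown: the limit of > 100000 nM in this assay, at which 2 of the 2 values shown sit.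

The next compound, compound 3, `COc1cc2c(cc1OC)CN(c1ccc(F)cc1)CC2`, keeps the core and changes only the substituent on that ring: fluoro in place of formyl on an aromatic carbon. Among the measured compounds shown here, no measured step connects the two, so the size of the change can only be expected. With compound 1 sitting at the limit and compound 2 likewise at the limit, compound 3 is expected to remain there as well, and the step that the limit leaves unreadable from compound 1 to compound 3 is expected to be none beyond the scatter. For compound 3 the estimate is 150000 nM, within the range 30000 nM to 1000000 nM.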

Compound 3, half-maximal inhibitory concentration in the Amine oxidase [flavin-containing] A assay: > 100000 nM
Compound 3: no number, only a limit; the forecaster's own chance of this, stated with the estimate: 85%; the middle value lies beyond the limit too.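

In the Amine oxidase [flavin-containing] A assay compound 3 gives > 100000 nM as a limit of the assay and not a number. Compound 1 also sits at a limit, so the step between compound 1 and compound 3 cannot be read. In a physicochemical assay for solubility, read by LC-MS, in phosphate buffer, with a stated time of 20 min, at pH 7.0, tested at 100 uM (a lower number here means a less soluble compound, a higher number a more soluble compound), compound 1 gives 6600 nM and compound 3 gives 20300 nM as measured values, which makes a 3.1-fold higher number from compound 1 to compound 3 (0.49 log units; beyond the scatter) on this read-out. The compounds shown leave open whether any substituent on this aromatic ring gives measurable inhibition.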